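Aryl change on the shared core: expectation for compound 4

A few compounds are considered here, and "the series" means these few. Any claim that something is new, unique, unknown or untested is made for them only; others in the source may bear on it.

Measured so far: compound 1 `COc1cc2ncnc(Nc3ccc(F)c(Cl)c3)c2cc1OCCCCC(=O)Nc1ccc(S(N)(=O)=O)cc1`, compound 2 `COc1cc2ncnc(Nc3ccc(Cl)cc3)c2cc1OCCCCC(=O)Nc1ccc(S(N)(=O)=O)cc1` and compound 3 `COc1cc2ncnc(Nc3ccc(F)c(Br)c3)c2cc1OCCCCC(=O)Nc1ccc(S(N)(=O)=O)cc1`. Compound 4 `COc1cc2ncnc(Nc3cc(F)c(F)c(F)c3)c2cc1OCCCCC(=O)Nc1ccc(S(N)(=O)=O)cc1` is not yet measured.

In a functional assay on A549 cells (Homo sapiens) for antiproliferative activity, read by MTT assay, with a stated time of 72 h (on this read-out lower numbers stand for stronger inhibition and higher numbers for weaker inhibition), compound 1 gives 15500 nM and compound 3 gives 16000 nM. Compound 2 reaches only > 40000 nM in this assay, which is a limit of the assay and not a number. Compound 2 thus stands at the weak end of the measured values, sitting at the limit of > 40000 nM in this assay, at which 1 of the 3 values shown sits.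

The step to compound 4 is 3,4,5-trifluorophenyl in place of 4-chlorophenyl on a nitrogen on an aromatic ring. Within the data shown here, two measured steps touch the same position: an at least 2.5-fold higher number from compound 1 to compound 2 (0.41 log units; beyond the scatter), and an at least 2.5-fold lower number from compound 2 to compound 3 (0.39 log units; beyond the scatter). In both, the 4-chlorophenyl compound gives the higher number than the fluorine-bearing partner, while a 1.0-fold higher number from compound 1 to compound 3 (0.01 log units; within the scatter) shows that exchanging bromo for chloro there changes nothing beyond the scatter. Among the measured compounds shown here, a 3,4,5-trifluorophenyl group has no measured counterpart, so the expectation rests only on the direction of those two steps: a modest move toward a lower number, of roughly their size, is expected, an at least 2.0-fold lower number from compound 2 to compound 4 (0.30 log units; that floor lies within the scatter). Compound 4 is accordingly estimated at 20000 nM, with a range from 8000 nM to 50000 nM, and a limit result for compound 4 remains possible.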

Compound 4, half-maximal inhibitory concentration: > 40000 nM
Compound 4 was reported as a limit (the forecaster's own chance of this, stated with the estimate: 35%); middle value at least 2.0-fold (0.30 log units) from the limit.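

Notes on the aryl group on the nitrogen: in this assay, the 3,4,5-trifluorophenyl group falls short of both aryl groups that gave a readable number, with an at least 2.5-fold higher number from compound 3 to compound 4 (0.39 log units; beyond the scatter) and an at least 2.5-fold higher number from compound 1 to compound 4 (0.41 log units; beyond the scatter). Fluorine on this ring is therefore not enough to keep a readable number: the earlier steps set fluorine-bearing partners against the 4-chlorophenyl compound, and compound 4 goes against that reading, while compound 1 and compound 3 still fit it. The step between the two limit compounds cannot be read, and the set now divides into two readable values and two limits, neither of which is a number: the limit of > 40000 nM in this assay, at which 2 of the 4 values shown sit.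

Still open, on these data alone, is how the 3,4,5-trifluorophenyl and 4-chlorophenyl compounds rank against each other, and whether a halogen is needed on this ring at all, a question that a plain phenyl group or a methoxyphenyl group would address. Also open, as far as these compounds go, is how much of the activity depends on the rest of the molecule, for instance with a longer chain in the linker or a carboxylic acid in place of the sulfonamide.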